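A few compounds are considered here, and "the series" means these few. Any claim that something is new, unique, unknown or untested is made for them only; others in the source may bear on it.

Working notes on the series

Compound 1 `Cc1ccc(S(=O)(=O)Nc2ccc3oc(-c4ccccc4)nc3c2)cc1` is the reference point here. In an assay on cells for inhibition of HSP60/HSP10 (Homo sapiens), with a stated time of 60 min (on this read-out higher numbers stand for weaker inhibition and lower numbers for stronger inhibition), compound 1 sits only at a limit of the assay, > 100000 nM, not at a measured number. Two further members share this core. Compound 2 `O=S(=O)(Nc1ccc(-c2nc3ccccc3o2)cc1)c1ccccc1O` likewise reaches only the limit in this assay, > 100000 nM. Compound 3 `C=Cc1ccc(S(=O)(=O)Nc2ccc(-c3nc4ccccc4o3)cc2)cc1` also stops at the limit in this assay, > 100000 nM. Within the data shown here, the one comparison that is formally a single change, 4-vinylphenyl in place of 2-hydroxyphenyl on a sulfonyl sulfur, gives a step that the two limits leave unreadable from compound 2 to compound 3, so its size cannot be read. The whole picture so far rests on (the limit of > 100000 nM in this assay, at which 3 of the 3 values shown sit).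

The next compound is compound 4 `O=S(=O)(Nc1ccc2oc(-c3ccccc3)nc2c1)c1ccccc1O`. It differs from compound 1 by 2-hydroxyphenyl in place of 4-methylphenyl on a sulfonyl sulfur. Among the measured compounds shown here, no measured step speaks directly to this change, and the one step that does involve a 2-hydroxyphenyl on a sulfonyl sulfur is unreadable, because of the limit of > 100000 nM in this assay, at which 3 of the 3 values shown sit, every value stands at the same limit. Accordingly no step beyond the scatter is expected in this assay, in either direction, and the expected change from compound 1 to compound 4 is a step that the limit leaves unreadable from compound 1 to compound 4. The estimate for compound 4 in this assay is therefore 150000 nM, with a range from 50000 nM to 500000 nM, and most likely the assay again reports only a limit.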

Compound 4, half-maximal inhibitory concentration: 85000 nM
Compound 4: the middle estimate sits 1.8-fold (0.25 log units) above what was measured; the range from low to high includes it.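

Among these compounds, compound 4 supplies the first value that is a measured number rather than a limit: in this assay, compound 4 gives 85000 nM. The change on the sulfonyl sulfur, 2-hydroxyphenyl in place of 4-methylphenyl, keeps a six-membered aromatic ring of carbon only there and brings in the hydrogen-bond donor and acceptor counted for 2-hydroxyphenyl, and it gives an at least 1.1-fold lower number from compound 1 to compound 4 (0.07 log units; that floor lies within the scatter). This floor does not show a change beyond the scatter, and the true size of the step stays unknown because the value for compound 1 is only a limit: the limit of > 100000 nM in this assay, at which 3 of the 4 values shown sit.

With one measured number in the series, the data show no trend at this position, and they do not separate the effect of the hydroxyl group from that of removing the methyl group. Also open, as far as these compounds go, is how an amine or a carboxylic acid on this aromatic ring, or a longer chain in place of the methyl group of 4-methylphenyl, would read in this assay.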